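Ethoxy for ethyl on the aromatic ring of compound 2

This account rests on a few compounds, and the source may have more. Where it says the series, first, only, none or still open, it means among the compounds named here.

The series shares the core of compound 2 `CCc1ccccc1OC(C)C1=NCCN1`, which in a functional assay on CHO cells for agonist activity at Alpha-2C adrenergic receptor (Homo sapiens) (on this read-out lower numbers stand for an effect already at smaller amounts and higher numbers for an effect only at larger amounts of compound), gives 100 nM. Compound 1 `C=COc1ccccc1OC(C)C1=NCCN1` carries vinyloxy on an aromatic carbon and gives 631 nM. Compound 3 `C=CCc1cccc(CC=C)c1OC(C)C1=NCCN1` gives 56.2 nM. Compound 2 thus stands second highest of the three numbers; its gap to compound 3 is within the scatter, while its step from compound 1, a 6.3-fold lower number from compound 1 to compound 2 (0.80 log units; beyond the scatter), lies beyond it.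

The next compound is compound 4 `CCOc1ccccc1OC(C)C1=NCCN1`, which differs from compound 2 in one place: ethoxy in place of ethyl on an aromatic carbon.

Going by the values given here, only one measured step bears on this change. The exchange of vinyloxy for ethyl on the aromatic carbon, a 6.3-fold lower number from compound 1 to compound 2 (0.80 log units; beyond the scatter), was a modest step toward lower numbers. Compound 4 reverses part of that exchange, since ethoxy, like vinyloxy, places an oxygen on the aromatic carbon, yet ethoxy is not vinyloxy, so the full step back is not expected. Among the compounds with values here, compound 3 offers no step to compound 2 and gives no further guidance.

For compound 4 a move toward higher numbers in this assay is expected, of size a 2.5-fold higher number from compound 2 to compound 4 (0.40 log units; beyond the scatter), smaller than the step from compound 1. Compound 4 is therefore estimated at 250 nM, with a range from 80 nM to 800 nM.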

Compound 4, half-maximal effective concentration: 10000 nM
For compound 4 the middle estimate is 40-fold (1.60 log units) below the measured one; the measured number lies above the stated range.
By their numbers in this assay, from the lowest: compounds 3 and 2 (each within the scatter of the next); then compound 1; then compound 4.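

In this assay, ethoxy in place of ethyl on this aromatic carbon gives a far larger move toward higher numbers than the earlier exchange at this place suggested (a 100-fold higher number from compound 2 to compound 4 (2.00 log units; beyond the scatter)). An oxygen on the aromatic carbon does not set the outcome on its own, since the two oxygen-linked groups also stand apart: ethyl in place of vinyl on that oxygen is itself a large step (a 16-fold higher number from compound 1 to compound 4 (1.20 log units; beyond the scatter)). At this position, a change confined to the group on the oxygen is thus enough to move the number strongly, and the data here hold no measurement that explains either step.

Still open, from the compounds shown here alone, is whether the high number of compound 4 follows from the size of the group on the oxygen or from its saturated ethyl chain, which methoxy, or a longer chain such as propoxy, at the same aromatic carbon would help to separate. Also open, going by these compounds, is how an amine or a carboxylic acid at this place would read out in this assay, and whether the ethoxy step holds on a core carrying further groups on the aromatic ring.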